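Ring Size of the Amine on the Amide Side Chain

The compounds below may be only part of what the source reports. "The series", "measured", "known", "first", "only" and "open" are said of these compounds alone.

Two compounds have been measured so far in a functional assay on PC-3 cells (Homo sapiens) for cytotoxicity, read by MTT assay, with a stated time of 48 h; on this read-out lower numbers stand for stronger inhibition and higher numbers for weaker inhibition:

Compound 1 `CCN(CC)CC(=O)N1N=C(C)CC1c1ccccc1O`: 25900 nM
Compound 2 `CC1=NN(C(=O)CN2CCCCC2)C(c2ccccc2O)C1`: 5890 nM

Going by the values given here, of these two numbers, compound 2 holds the lower one; its only neighbour is compound 1, and the two are separated by the step of a 4.4-fold lower number from compound 1 to compound 2 (0.64 log units; beyond the scatter), which stands beyond the scatter. Compound 3 `CC1=NN(C(=O)CN2CCCC2)C(c2ccccc2O)C1` differs from compound 2 by pyrrolidin-1-yl in place of piperidin-1-yl on a saturated chain carbon bound to a carbonyl carbon. Among the compounds with values here, no measured step shows this exact exchange. Within the data shown here, the one step that bears on the same place, a 4.4-fold lower number from compound 1 to compound 2 (0.64 log units; beyond the scatter), is modest and shows that the amine at this position can move the number, but the entering group here is neither of the two groups already compared. Compound 3 is therefore expected to stay close to compound 2, with an estimate of 8000 nM and a range from 3000 nM to 25000 nM. The step of a 1.4-fold higher number from compound 2 to compound 3 (0.13 log units; within the scatter) that this estimate implies is expected to lie within the usual scatter, so no clear change in direction is predicted.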

Compound 3, half-maximal inhibitory concentration: 6670 nM
Beside the measured number, compound 3's estimate is 1.2-fold (0.08 log units) above it, and the stated range covers the measured number.
By their numbers in this assay, from the lowest: compounds 2 and 3 (each within the scatter of the next); then compound 1.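

In this assay, the step of a 1.1-fold higher number from compound 2 to compound 3 (0.05 log units; within the scatter) shows that pyrrolidin-1-yl and piperidin-1-yl cannot be told apart on a saturated chain carbon bound to a carbonyl carbon, so the exchange of a six-membered for a five-membered non-aromatic ring gives no readable change in this series. The step of a 3.9-fold lower number from compound 1 to compound 3 (0.59 log units; beyond the scatter) shows that the gap from diethylamino, until now seen only as a 4.4-fold lower number from compound 1 to compound 2 (0.64 log units; beyond the scatter), is not confined to piperidin-1-yl: among these three compounds, both ring amines give lower numbers than the open diethylamino group, and no listed compound goes against this. Nothing available gives a reason for this result.

The compounds shown leave open whether a ring amine carrying another hetero atom, such as morpholin-4-yl or 4-methylpiperazin-1-yl, or a larger ring such as azepan-1-yl, would stay with compound 2 and compound 3 or move the number. They also leave open whether a longer chain carrying the same amines, in place of the single saturated chain carbon, would keep the gap from compound 1.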